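The source may report more compounds than this note shows. Statements on the series, on what has been measured and on what is new or still open speak of the compounds shown alone.

Compounds measured in an ADME assay on RAW264.7 cells (Mus musculus) for cytotoxicity, read by MTT assay, with a stated time of 72 h, tested at 50 uM; on this read-out higher numbers stand for more inhibition at the one concentration tested (going by the name of the read-out) and lower numbers for less inhibition:

compound 1, `CCOC(=O)c1sc(-c2ccncc2)nc1N1CCC(NCc2ccccc2)CC1`: 10.8%
compound 2, `CCOC(=O)c1sc(-c2ccncc2)nc1N1CCC(NCc2ccc(C(F)(F)F)cc2)CC1`: 18.1%
compound 3, `CCOC(=O)c1sc(-c2ccncc2)nc1N1CCC(NCc2ccc(Cl)c(Cl)c2)CC1`: 32.2%

Within this small set compound 3 gives the highest number in this assay: its nearest neighbour is compound 2, reached by a number 14.1 percentage points higher from compound 2 to compound 3 (beyond the scatter), and the furthest is compound 1, reached by a number 21.4 percentage points higher from compound 1 to compound 3 (beyond the scatter). The comparison of compound 1 with compound 2, a number 7.3 percentage points higher from compound 1 to compound 2 (within the scatter), stays within the scatter.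

Compound 4, `CCOC(=O)c1sc(-c2ccncc2)nc1N1CCC(NCc2ccc(Cl)cc2Cl)CC1`, has not yet been measured in this assay. It differs from compound 3 only in the arrangement of the two chlorine atoms on the benzyl ring: 2,4-dichlorophenyl in place of 3,4-dichlorophenyl on a saturated chain carbon bound to an amine nitrogen

The two steps that bear on this change are those leading into compound 3, a number 21.4 percentage points higher from compound 1 to compound 3 (beyond the scatter) and a number 14.1 percentage points higher from compound 2 to compound 3 (beyond the scatter), both modest and both beyond the scatter; they show that adding two chlorines to the ring raised the number. Among the measured compounds shown here, no measured step moves a chlorine from one ring position to another, so the effect of the rearrangement itself is untested. Keeping the same number of chlorines, compound 4 is expected to stay close to compound 3, with a step of a number 4.2 percentage points lower from compound 3 to compound 4 (within the scatter) that could fall either way within the scatter. Compound 4 is therefore estimated at 28%, with a range from 14% to 42%.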

Compound 4, a percentage reported as inhibition, at one concentration (the size of the read-out at that concentration, not a potency): 18.4%
Compound 4: middle estimate off by 9.6 percentage points, on the high side, and the stated range covers the measured number.
By their numbers in this assay, from the lowest: compounds 1, 2 and 4 (each within the scatter of the next); then compound 3.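

In this assay, the arrangement of the two chlorines on the benzyl ring matters at this position, not only their presence: with the same atoms joined differently, the change from 3,4-dichlorophenyl to 2,4-dichlorophenyl gives a number 13.8 percentage points lower from compound 3 to compound 4 (beyond the scatter). The earlier compounds could be read as showing that two chlorines on the ring are enough to raise the number, but 2,4-dichlorophenyl does not separate from the other two groups, with a number 0.3 percentage points higher from compound 2 to compound 4 (within the scatter) and a number 7.6 percentage points higher from compound 1 to compound 4 (within the scatter), so among these four compounds only the 3,4-dichlorophenyl group stands apart. No measured evidence accounts for the gap between the two dichlorophenyl arrangements.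

The compounds shown leave open whether a single chlorine on the ring, or a methoxy or nitrile group in its place, would go with compound 3 or with the other three compounds. They also leave open whether the difference between the two dichlorophenyl groups persists when the ethyl ester on the shared core is replaced by a carboxylic acid or an amide.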